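Removing the Methyl from Compound 1's Chlorophenyl Ring

The source may report more compounds than this note shows. Statements on the series, on what has been measured and on what is new or still open speak of the compounds shown alone.

Compound 1 `Cc1nc(-c2ccccc2F)c(C(=O)N2CCN(c3cc(Cl)ccc3C)CC2)o1` is examined in a functional assay on HL-60 cells (Homo sapiens) for inhibition, read by MTT assay, with a stated time of 72 h (a lower number here means a stronger inhibitor, a higher number a weaker inhibitor), where compound 1 gives 229 nM. This is the highest of the three numbers in hand, but its nearest neighbour, compound 3 `Cc1nc(-c2ccccc2)c(C(=O)N2CCN(c3c(C)cccc3C)CC2)o1`, gives 146 nM, and the furthest, compound 2 `Cc1nc(-c2ccccc2)c(C(=O)N2CCN(c3ccccc3Cl)CC2)o1`, gives 124 nM; both gaps lie within the scatter, so the three compounds cannot be separated on these numbers.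

The step under study leads to compound 4 `Cc1nc(-c2ccccc2F)c(C(=O)N2CCN(c3cccc(Cl)c3)CC2)o1`, which differs from compound 1 in one place: hydrogen in place of methyl on an aromatic carbon Cut one bond further out, this reads as 5-chloro-2-methylphenyl to 3-chlorophenyl.

Going by the values given here, no measured step removes a methyl in this way. Among the compounds with values here, the only step available, a 1.2-fold higher number from compound 2 to compound 3 (0.07 log units; within the scatter), exchanged the whole substituent pattern on that ring and moved the number within the scatter. With only that to go on, the change from compound 1 to compound 4 is expected to give a step of about a 1.0-fold higher number from compound 1 to compound 4 (0.00 log units; within the scatter), which is to say none beyond the scatter in this assay.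

Compound 4 is therefore estimated to give 230 nM in this assay, with a range from 100 nM to 520 nM.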

Compound 4, half-maximal inhibitory concentration: 39.4 nM
For compound 4 the middle estimate is 5.8-fold (0.77 log units) above the measured one, and the stated range ends above it.
By their numbers in this assay, from the lowest: compound 4; then compounds 2, 3 and 1 (each within the scatter of the next).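

In this assay, the aromatic carbon ortho to a large group and para to a chloro group proves to matter: with hydrogen in place of methyl there, the result is a 5.8-fold lower number from compound 1 to compound 4 (0.76 log units; beyond the scatter), a step beyond the scatter. Going by these compounds alone, the earlier step, a 1.2-fold higher number from compound 2 to compound 3 (0.07 log units; within the scatter), exchanged the whole substituent pattern on this ring and stayed within the scatter, so the earlier compounds gave no sign that a change on this ring could move the number at all, whereas here the loss of a single methyl, going from 5-chloro-2-methylphenyl to 3-chlorophenyl, does so. Nothing available bears on why this single change moves the number.

The compounds shown leave open whether the methyl is unique at this carbon, or whether an ethyl, a methoxy group or a fluoro group there would leave the number near that of compound 4 or near that of compound 1. They also leave open whether the same exchange would give a step of similar size with the 2-chlorophenyl group of compound 2, or with a bromo group in place of the chloro group.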